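A few compounds are considered here, and "the series" means these few. Any claim that something is new, unique, unknown or untested is made for them only; others in the source may bear on it.

Working notes on the series, read in a functional assay on HCT-116 cells (Homo sapiens) for antiproliferative activity, read by MTT assay, with a stated time of 24 h; a lower number here means a stronger inhibitor, a higher number a weaker inhibitor. Compound 1 (`COc1ccc(/C=C/C(=O)c2ccc(OC)c3c2OC(C)(C)C=C3)c(F)c1`) gives > 10000 nM, which is a limit of the assay. Going by the values given here, compound 2 (`COc1ccc(C(=O)/C=C/c2ccc([N+](=O)[O-])cc2)c2c1C=CC(C)(C)O2`) gives 8880 nM, the only reading so far that is a number. Compound 3 (`COc1ccc(C(=O)/C=C/c2ccsc2)c2c1C=CC(C)(C)O2`) gives > 10000 nM, which is also a limit, so its standing is known only as that limit. The readings are bounded by the limit of > 10000 nM in this assay, at which 2 of the 3 values shown sit.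

The next change leads to compound 4 (`COc1ccc(C(=O)/C=C/c2ccc(Cl)c(Cl)c2)c2c1C=CC(C)(C)O2`): 3,4-dichlorophenyl in place of thiophen-3-yl on a double-bonded chain carbon bound to a double-bonded chain carbon. It places 3,4-dichlorophenyl on the same double-bonded chain carbon, where all three measured steps also fall. an at least 1.1-fold lower number from compound 1 to compound 2 (0.05 log units; that floor lies within the scatter) and an at least 1.1-fold higher number from compound 2 to compound 3 (0.05 log units; that floor lies within the scatter) have floors within the scatter, and a step that the two limits leave unreadable from compound 1 to compound 3 cannot be read from its two limits. Among the compounds with values here, with compound 2 at 8880 nM as the only number, no step beyond the scatter is expected here, and the direction stays open. The estimated step is an at least 1.4-fold lower number from compound 3 to compound 4 (0.15 log units; that floor lies within the scatter). Compound 4 is expected at 7000 nM, with an estimated range of 2500 nM to 15000 nM.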

Compound 4, half-maximal inhibitory concentration: 9440 nM
The estimate for compound 4 lay 1.3-fold (0.13 log units) below the measured number, and the stated range covers the measured number.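

At this double-bonded chain carbon, 3,4-dichlorophenyl is the second group to give a number rather than a limit, and against 4-nitrophenyl in this assay the result is a 1.1-fold higher number from compound 2 to compound 4 (0.03 log units; within the scatter), so these two groups cannot be told apart. Against the two groups that gave limits, the result is only a floor, an at least 1.0-fold lower number from compound 3 to compound 4 (0.02 log units; that floor lies within the scatter) and an at least 1.0-fold lower number from compound 1 to compound 4 (0.02 log units; that floor lies within the scatter), so neither thiophen-3-yl nor 2-fluoro-4-methoxyphenyl can be ranked against 3,4-dichlorophenyl; the steps between limits cannot be read. The readings remain bounded by a limit of the assay: the limit of > 10000 nM in this assay, at which 2 of the 4 values shown sit.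

No readable step shown at this place lies beyond the scatter, so whether any group there can shift the number remains open. Going by these compounds, the outcome with an amine or a carboxylic acid at this place, or with a change on the shared core, also remains open.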